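A Fluorine Swap on the Methoxyphenyl Ring

This account rests on a few compounds, and the source may have more. Where it says the series, first, only, none or still open, it means among the compounds named here.

Of the compounds shown here, two have been measured in a functional assay on MDA-MB-231 cells (Homo sapiens) for antiproliferative activity, read by MTT assay, with a stated time of 48 h; a higher number here means a weaker inhibitor, a lower number a stronger inhibitor. Compound 1 `COc1ccc(N(C)c2ccnc(Cl)n2)cc1OCC[Se]C#N` gives 2750 nM. Compound 2 `COc1ccc(N(C)c2cc(C)nc(C)n2)cc1` gives 3650 nM, the higher of the two numbers shown, though the two lie within the usual scatter of each other, so no order between them can be claimed. Compound 3 `COc1ccc(N(C)c2cc(C)nc(C)n2)cc1F` has not yet been measured; it differs from compound 2 by fluoro in place of hydrogen on an aromatic carbon. Among the compounds with values here, no measured pair here shows what such a swap does, so the expectation rests on the single anchor of compound 2. The step from compound 2 to compound 3 in this assay is expected to be small, in either direction or none beyond the scatter, a 1.2-fold lower number from compound 2 to compound 3 (0.09 log units; within the scatter). Compound 3 is therefore estimated at 3000 nM, with a range from 1200 nM to 7500 nM.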

Compound 3, half-maximal inhibitory concentration: 2790 nM
Estimate against measurement, compound 3: 1.1-fold (0.03 log units) above, and the stated range covers the measured number.
By their numbers in this assay, from the lowest: compounds 1, 3 and 2 (each within the scatter of the next).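

Within the data shown here, the step of a 1.3-fold lower number from compound 2 to compound 3 (0.12 log units; within the scatter) in this assay is the first reading of what fluoro in place of hydrogen does on this aromatic carbon, ortho to a methoxy group. Because the step lies within the scatter, this one change leaves the antiproliferative reading indistinguishable from that of the parent, and no gain or loss can be claimed. No outside measurement bears on this result or offers an explanation for it.

From the compounds shown here alone, it remains open whether a different group on this same carbon, such as an amine, a hydroxyl or a carboxylic acid, would move the number beyond the scatter. Going by these compounds, it is also open whether fluoro here would give a similarly small step on the core of compound 1, since a single pair cannot show a general pattern.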